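Shrinking the ring on the amide nitrogen

A few compounds are considered here, and "the series" means these few. Any claim that something is new, unique, unknown or untested is made for them only; others in the source may bear on it.

Measured compounds:
- compound 1 `O=C1COc2ccc(-c3cnc(Cl)c(NS(=O)(=O)c4ccc(F)cc4)c3)cc2N1C1CCCCC1`: 14300 nM
- compound 2 `COc1ncc(-c2ccc3c(c2)N(C2CCCCC2)C(=O)CO3)cc1NS(=O)(=O)c1ccc(F)cc1`: 6100 nM
- compound 3 `O=C1COc2ccc(-c3cccc(NS(=O)(=O)c4ccc(F)cc4)c3)cc2N1c1ccc(Cl)cc1`: 35000 nM

All three compounds were tested in a functional assay on HeLa cells (Homo sapiens) for antiproliferative activity, read by MTT assay, with a stated time of 72 h; on this read-out lower numbers stand for stronger inhibition and higher numbers for weaker inhibition. Compound 1 stands second highest of the three numbers. Its nearest neighbour is compound 2, which gives 6100 nM; the one-place step between them, a 2.3-fold lower number from compound 1 to compound 2 (0.37 log units; beyond the scatter), is modest but beyond the scatter. Within the data shown here, compound 3 gives 35000 nM, the highest of the three, but it differs from compound 1 in more than one place, so no single step connects them.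

Compound 4 `O=C1COc2ccc(-c3cnc(Cl)c(NS(=O)(=O)c4ccc(F)cc4)c3)cc2N1C1CC1` differs from compound 1 by cyclopropyl in place of cyclohexyl on an amide-type nitrogen in a ring. Among the measured compounds shown here, no measured step touches this nitrogen alone: the only clean step, from compound 1 to compound 2, concerns the chloro group on an aromatic carbon, and compound 3 changes both the nitrogen substituent and the aromatic ring at once. With no guide for this change, the expectation is a step of a 1.4-fold higher number from compound 1 to compound 4 (0.15 log units; within the scatter) in this assay, not beyond the scatter. Compound 4 is therefore estimated at 20000 nM, within a range of 6000 nM to 70000 nM.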

Compound 4, half-maximal inhibitory concentration: 7180 nM
Compound 4: middle estimate off by 2.8-fold (0.44 log units), on the high side, within the range that was stated.
By their numbers in this assay, from the lowest: compounds 2, 4 and 1 (each within the scatter of the next, the first and the last beyond it); then compound 3.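

In this assay, among these compounds, swapping cyclohexyl for cyclopropyl on the amide-type nitrogen gives a 2.0-fold lower number from compound 1 to compound 4 (0.30 log units; within the scatter), the first reading of this position on its own. With 3 heavy atoms in the group in place of 6, the two compounds cannot be told apart in this read-out, so between these two carbon rings the size of the ring does not separate them. Nothing in the data at hand explains why the two numbers stay this close.

From the compounds shown here alone, it remains open how this nitrogen would respond to a group of another kind, such as a simple methyl, a longer chain or a chain ending in an amine. Going by these compounds, it is also open what cyclopropyl would give when paired with the methoxy group of compound 2.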